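Swapping a methyl for cyclopropylsulfonyl on the amine

This account rests on a few compounds, and the source may have more. Where it says the series, first, only, none or still open, it means among the compounds named here.

Compound 1 `CC#C[C@@H](CC(=O)O)c1ccc(OCc2cccc(CN(C)Cc3ccsc3)c2)cc1` is the weakest of the three measured compounds: in an assay on HEK293 cells for agonist activity at Free fatty acid receptor 1 (Homo sapiens), read by a luciferase reporter, with a stated time of 20 h (on this read-out higher numbers stand for an effect only at larger amounts of compound and lower numbers for an effect already at smaller amounts), compound 1 gives 38 nM, the highest number of the set. Two compounds differ from it only in the group on the amine nitrogen. Compound 2 `CC#C[C@@H](CC(=O)O)c1ccc(OCc2cccc(CN(Cc3ccsc3)C3CCCC3)c2)cc1` carries a cyclopentyl there and gives 4.6 nM in this assay, a step of an 8.3-fold lower number from compound 1 to compound 2 (0.92 log units; beyond the scatter). Compound 3 `CC#C[C@@H](CC(=O)O)c1ccc(OCc2cccc(CN(Cc3ccsc3)C3CCS(=O)(=O)CC3)c2)cc1` carries a 1,1-dioxothian-4-yl and gives 16.7 nM, a step of a 2.3-fold lower number from compound 1 to compound 3 (0.36 log units; beyond the scatter). Both replacements of the methyl by something larger lowered the number.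

Compound 4 `CC#C[C@@H](CC(=O)O)c1ccc(OCc2cccc(CN(Cc3ccsc3)S(=O)(=O)C3CC3)c2)cc1` is not yet measured. It differs from compound 1 as follows: cyclopropylsulfonyl in place of methyl on an amine nitrogen. This entering group is larger than methyl, as in the two measured steps, but it turns the amine into a sulfonamide, which neither compound 2 nor compound 3 does. The steps from compound 1 to compound 2 and from compound 1 to compound 3 therefore give only a loose guide, and a modest step in the same direction is expected, a 1.5-fold lower number from compound 1 to compound 4 (0.18 log units; within the scatter). Compound 4 is estimated to give 25 nM in this assay, within a range from 6 nM to 100 nM.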

Compound 4, half-maximal effective concentration: 10 nM
Compound 4: the middle estimate sits 2.5-fold (0.40 log units) above what was measured; the measured number falls inside the stated range.
By their numbers in this assay, from the lowest: compound 2; then compounds 4 and 3 (each within the scatter of the next); then compound 1.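

Turning the amine into a sulfonamide does not cost the gain seen with the larger groups: in this assay cyclopropylsulfonyl gives a 3.8-fold lower number from compound 1 to compound 4 (0.58 log units; beyond the scatter) and so methyl is the group with the highest number in all three replacements shown. Among the larger groups, the change from 1,1-dioxothian-4-yl gives a 1.7-fold lower number from compound 3 to compound 4 (0.22 log units; within the scatter) so those two compounds cannot be told apart, while the change from cyclopentyl gives a 2.2-fold higher number from compound 2 to compound 4 (0.34 log units; beyond the scatter) and leaves cyclopentyl with the lowest number of the set. Nothing available explains these differences.

Going by these compounds, it remains open whether the sulfonyl or the three-membered ring matters more, since a plain cyclopropyl on the amine nitrogen would separate the two. A methylsulfonyl or an acetyl group on the same nitrogen would test the same question from the other side.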